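A few compounds are considered here, and "the series" means these few. Any claim that something is new, unique, unknown or untested is made for them only; others in the source may bear on it.

Working notes on the series. In a functional assay on MCF7 cells (Homo sapiens) for cytotoxicity, read by CCK-8 assay, with a stated time of 24 h (a lower number here means a stronger inhibitor, a higher number a weaker inhibitor), compound 1 `C/C(=C\c1cc(C2=CCCC2)co1)C(N)=O` gives 15000 nM, and compound 2 `C/C(=C\c1cc(-c2ccccc2)cs1)C(N)=O` gives 2680 nM. Compound 2 has the lowest of the two numbers recorded in this assay; compound 1 stands a good way above it, the gap between the two being beyond the usual scatter of repeated measurements, so compound 2 is the stronger inhibitor of the pair on these two numbers alone. Within the data shown here, no step between measured compounds that differ in one place has been recorded, so there is no direct precedent for the change now considered.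

Compound 3 `C/C(=C\c1cc(-c2ccc(C)cc2)cs1)C(N)=O` has not been measured in this assay. It differs from compound 2 as follows: methyl in place of hydrogen on an aromatic carbon. For a single methyl added on an aromatic carbon in this way, the expected step of a 1.2-fold lower number from compound 2 to compound 3 (0.09 log units; within the scatter) is small, likely within the scatter, with no firm direction. Compound 3 is therefore estimated at 2200 nM in this assay, with a range from 800 nM to 6000 nM.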

Compound 3, half-maximal inhibitory concentration: > 50000 nM
Compound 3 was reported as a limit; the forecaster's own chance of this, stated with the estimate: 5%; middle value at least 22-fold (1.35 log units) away from the limit.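

In this assay compound 3 gives > 50000 nM as a limit of the assay and not as a number. Among these compounds, a single methyl in place of hydrogen on an aromatic carbon, para to a large group, produces an at least 18-fold higher number from compound 2 to compound 3 (1.27 log units; beyond the scatter) and so gives the first direct reading at this position: here, the addition of 1 heavy atom is far from a neutral change, which the earlier pair could not show. The full size of the step cannot be read, as it rests on a limit: the limit of > 50000 nM in this assay, at which 1 of the 3 values shown sits.

Going by these compounds, whether the same loss would follow from fluorine, methoxy or a carboxylic acid at this position remains open. Also open, on these data alone, is how a methyl on another carbon of the same ring would compare with compound 2.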